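A few compounds are considered here, and "the series" means these few. Any claim that something is new, unique, unknown or untested is made for them only; others in the source may bear on it.

Measured compounds:
compound 1 `C=CC(=O)Nc1cccc(-n2c(=O)cc(C)c3cnc(Nc4ccccc4Nc4nc5c(s4)CN(C)CC5)nc32)c1` 3380 nM
compound 2 `C=CC(=O)Nc1cc(-n2c(=O)cc(C)c3cnc(Nc4ccc(N5CCN(C)C(C)C5)cc4OC)nc32)cc(C(F)(F)F)c1` 427 nM

In an ADME assay on the whole organism (strain Sprague-Dawley) for pharmacokinetics, with Rattus norvegicus as the target, read by LC-MS, at a dose of 5 mg/kg by the intravenous route (on this read-out higher numbers stand for higher exposure at the dose given and lower numbers for lower exposure), compound 1 gives 3380 nM and compound 2 gives 427 nM, so compound 2 stands lowest of the two, beyond the scatter from compound 1. Compound 3 `C=CC(=O)Nc1cccc(-n2c(=O)cc(C)c3cnc(Nc4ccc(N5CCN(C)C(C)C5)cc4OC)nc32)c1` differs from compound 2 by hydrogen in place of trifluoromethyl on an aromatic carbon. Because compound 1, which also carries hydrogen at that place, gives 3380 nM, a modest rise beyond the scatter is expected, though compound 1 differs elsewhere too. The estimated step of a 2.2-fold higher number from compound 2 to compound 3 (0.35 log units; beyond the scatter) points upward. Compound 3 is expected to give 950 nM, within 350 nM to 2600 nM.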

Compound 3, maximal plasma concentration: 2470 nM
Compound 3: middle estimate off by 2.6-fold (0.41 log units), on the low side, within the range that was stated.
By their numbers in this assay, from the lowest: compound 2; then compounds 3 and 1 (each within the scatter of the next).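

In this assay, hydrogen in place of trifluoromethyl on an aromatic carbon, meta to a (vinylcarbonyl)amino group, gives a 5.8-fold higher number from compound 2 to compound 3 (0.76 log units; beyond the scatter). Within the data shown here, this is the first change in a single place, and it shows that this position alone can shift the read-out beyond the scatter. No measurement shown here accounts for the step. As far as these compounds go, whether a methyl, a chlorine or a nitrile on this carbon would stay close to hydrogen or to trifluoromethyl remains open. So does whether the step would hold with a different group on the shared core.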